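Replacing allyl(methyl)amino on a carbonyl carbon in compound 2

The compounds below may be only part of what the source reports. "The series", "measured", "known", "first", "only" and "open" are said of these compounds alone.

Compound 1 `CCN(CC)CCCNC(=O)c1ccc(C(CC)(CC)c2ccc(OCC(O)C(C)(C)C)c(C)c2)n1CC`: 2500 nM
Compound 2 `C=CCN(C)C(=O)c1ccc(C(CC)(CC)c2ccc(OCC(O)C(C)(C)C)c(C)c2)n1CC`: 6300 nM

In an ADME assay on L02 cells (Homo sapiens) for cytotoxicity, read by MTT assay, with a stated time of 48 h (a higher number here means a weaker inhibitor, a lower number a stronger inhibitor), compound 2 gives 6300 nM, the higher of the two numbers measured, and compound 1 stands lower at 2500 nM. Compound 3 `CCn1c(C(=O)Oc2ccc(CCO)cc2)ccc1C(CC)(CC)c1ccc(OCC(O)C(C)(C)C)c(C)c1` has not yet been measured. It departs from compound 2 in one place: a group of 10 heavy atoms (8 carbon, 2 oxygen; one six-membered aromatic ring of carbon only) in place of a group of 5 heavy atoms (4 carbon, 1 nitrogen; no ring), on a carbonyl carbon. Among the compounds with values here, only one measured step bears on this change, and it falls on a carbonyl carbon too: a 2.5-fold higher number from compound 1 to compound 2 (0.40 log units; beyond the scatter). That step is modest, and it gives no direction for the new group, since neither measured compound carries anything like it. No clear shift is therefore expected, and a modest one either way would not surprise. The estimated step is a 1.1-fold lower number from compound 2 to compound 3 (0.02 log units; within the scatter), expected to stay within the scatter. For compound 3 the expected value is 6000 nM, with an estimated range of 2200 nM to 16000 nM.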

Compound 3, half-maximal inhibitory concentration: 22700 nM
Compound 3: the middle estimate sits 3.8-fold (0.58 log units) below what was measured; measured number above the stated range.
By their numbers in this assay, from the lowest: compound 1; then compound 2; then compound 3.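

In this assay, the group with one six-membered aromatic ring of carbon only, set in place of allyl(methyl)amino, gives a 3.6-fold higher number from compound 2 to compound 3 (0.56 log units; beyond the scatter) and so leaves compound 3 with the highest number of the three. Set in place of (3-(diethylamino)propyl)amino, the same group gives a 9.1-fold higher number from compound 1 to compound 3 (0.96 log units; beyond the scatter) and thereby widens the span seen at this carbonyl carbon, which now holds a group without nitrogen as well as two with it. Nothing available here accounts for this rise.

On these data alone, it remains open whether the rise goes with the aromatic ring, with its hydroxyl-bearing chain or with the loss of nitrogen on the carbonyl carbon. An amide bearing the same ring, or a plain carboxylic acid at this carbonyl carbon, could begin to separate these readings.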